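The source may hold more compounds than are shown below. What is called first, only, known or untested is meant among the compounds shown, and "the series" means these compounds.

Compound 1, `CCCCCc1cc(C)c(C(=O)N=C(N)N)cc1S(C)(=O)=O`, in a functional assay for inhibition of sodium/hydrogen exchanger (Oryctolagus cuniculus) (on this read-out lower numbers stand for stronger inhibition and higher numbers for weaker inhibition), gives 27 nM.
Compound 2, `Cc1cc(-c2ccc(F)cc2)c(S(C)(=O)=O)cc1C(=O)N=C(N)N`, in this assay gives 36 nM.
Compound 3, `CCOc1cc(C)c(C(=O)N=C(N)N)cc1S(C)(=O)=O`, in this assay gives 19 nM.

The three share a core and differ only in the group carried on one aromatic carbon: a pentyl chain, a 4-fluorophenyl, or an ethoxy. None of these swaps moved the number beyond the scatter: a 1.3-fold higher number from compound 1 to compound 2 (0.12 log units; within the scatter), a 1.4-fold lower number from compound 1 to compound 3 (0.15 log units; within the scatter) and a 1.9-fold lower number from compound 2 to compound 3 (0.28 log units; within the scatter). Compound 3 thus sits among the others without a gap that can be called real.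

Compound 4, `Cc1cc(OC2CCCC2)c(S(C)(=O)=O)cc1C(=O)N=C(N)N`, keeps the oxygen of compound 3 and changes what hangs on it: cyclopentyl in place of ethyl on an oxygen on an aromatic ring. For the measured compounds named here, no measured step alters the group on this oxygen, so the closest guide is the general picture that changes at this position, even between groups as unlike as a chain, a fluorinated ring and an ethoxy, stayed within the scatter. A step of similar smallness is expected here. Compound 4 is therefore estimated at 20 nM in this assay, within a range of 8 nM to 50 nM. This corresponds to an expected step of a 1.1-fold higher number from compound 3 to compound 4 (0.02 log units; within the scatter).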

Compound 4, half-maximal inhibitory concentration: 27 nM
Beside the measured number, compound 4's estimate is 1.4-fold (0.13 log units) below it; low and high end bracket the measured number.
By their numbers in this assay, from the lowest: compounds 3, 1, 4 and 2 (each within the scatter of the next).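

This is the only step shown that alters the group on the oxygen itself: a five-membered ring of carbon only replaces ethyl, and in this assay the result is small (a 1.4-fold higher number from compound 3 to compound 4 (0.15 log units; within the scatter)). Compared with the groups on the same aromatic carbon in the other two compounds, cyclopentyloxy also stays within the scatter (a 1.3-fold lower number from compound 2 to compound 4 (0.12 log units; within the scatter); no change at the digits printed from compound 1 to compound 4 (within the scatter)), so a chain, an aromatic ring, a short ether and a ring-bearing ether cannot be told apart at this position. Nothing available explains why the number stays so steady across these groups.

As far as these compounds go, whether an amine or a carboxylic acid on this aromatic carbon would keep the number within the same range remains open. So does the outcome of a longer chain or a six-membered ring on the oxygen.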